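The compounds below may be only part of what the source reports. "The series", "measured", "known", "first", "only" and "open" are said of these compounds alone.

Of the compounds shown here, two have numbers so far in a functional assay on SK-OV-3 cells (Homo sapiens) for inhibition, read by CCK-8 assay, with a stated time of 70 h; a lower number here means a stronger inhibitor, a higher number a weaker inhibitor. Compound 1 (`Clc1ccc(COc2ccc(OCCOCCNC3CCCCC3)cc2)cc1`) gives 2650 nM. Compound 2 (`c1ccc(COc2ccc(OCCOCCNc3ccncc3)cc2)cc1`) gives 20600 nM, the higher of the two numbers and beyond the scatter from the other.

Compound 3 (`c1ccc(COc2ccc(OCCOCCNC3CCCCC3)cc2)cc1`) has not yet been measured. It follows from compound 2 with cyclohexyl in place of pyridin-4-yl on an amine nitrogen. Going by the values given here, no two measured compounds differ in one place only, so this change has no measured step of its own. The nearest guide is compound 1, which also carries cyclohexyl on the amine nitrogen and gives 2650 nM. One compound is thin support, so the range is kept wide.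

A lower number, meaning a stronger inhibitor, is expected in this assay, by a step beyond the scatter. The expected step is a 6.9-fold lower number from compound 2 to compound 3 (0.84 log units; beyond the scatter). For compound 3 the estimated value is 3000 nM, with an expected range from 1200 nM to 7500 nM.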

Compound 3, half-maximal inhibitory concentration: 7370 nM
Compound 3: middle estimate off by 2.5-fold (0.39 log units), on the low side; measured number inside the range.
By their numbers in this assay, from the lowest: compound 1; then compound 3; then compound 2.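

In this assay the amine nitrogen now has a single-place reading: with the rest of the structure unchanged, cyclohexyl in place of pyridin-4-yl gives a 2.8-fold lower number from compound 2 to compound 3 (0.45 log units; beyond the scatter), so the ring on this nitrogen affects the number by a modest step beyond the scatter. The aromatic carbon that carries chloro in compound 1 also has its first single-place reading, as hydrogen in place of chloro gives a 2.8-fold higher number from compound 1 to compound 3 (0.44 log units; beyond the scatter), so the number responds to changes at both places, with the weaker side lying with hydrogen on the aromatic carbon and with pyridin-4-yl on the amine nitrogen. No measurement on these compounds speaks to the reason for either step.

Going by these compounds, the chloro step is read only with cyclohexyl on the amine nitrogen, and the cyclohexyl step only with hydrogen on the aromatic carbon, so whether each holds in the other setting remains open. Also open, on these data alone, is how the number responds to other groups at these two places, such as phenyl, cyclopentyl or an open butyl chain on the amine nitrogen, or fluoro or methoxy on the aromatic carbon.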